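A few compounds are considered here, and "the series" means these few. Any claim that something is new, unique, unknown or untested is made for them only; others in the source may bear on it.

Measured so far in an ADME assay (liver) for metabolic stability, with Liver microsome (Homo sapiens) as the target, read by LC-MS, using microsomes and NADPH, tested at 1 uM; a higher number here means that the compound lasts longer, a lower number that the compound disappears faster:
- compound 1, `CC(C)(C)c1cc(NC(=O)[C@@H]2CCCCN2CC2CC2)no1`: 0.15 h
- compound 2, `CCC(=O)N1CCN(C(=O)N2CCCC[C@H]2C(=O)Nc2cc(C(C)(C)C)on2)CC1`: a limit of the assay, > 2 h

Compound 2 therefore stands at the upper edge of what this assay reports (the limit of > 2 h in this assay, at which 1 of the 2 values shown sits), and no exact half-life is known for it. Compound 3, `CC(C)(C)c1cc(NC(=O)[C@@H]2CCCCN2C(=O)N2CC[S+]([O-])CC2)no1`, differs from compound 2 in one place: a group of 7 heavy atoms (4 carbon, 1 nitrogen, 1 oxygen, 1 sulfur; one six-membered non-aromatic ring with 2 hetero atoms) in place of a group of 10 heavy atoms (7 carbon, 2 nitrogen, 1 oxygen; one six-membered non-aromatic ring with 2 hetero atoms), on a carbonyl carbon. Among the compounds with values here, no measured pair shows this change, so its effect is unknown. The expected step is a number no higher from compound 2 to compound 3 (the limit leaves the size open), within the usual scatter, with a fair chance that only a limit is reported again. Compound 3 is estimated at 2 h, between 0.8 h and 4 h.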

Compound 3, half-life in the Liver microsome assay: > 2 h
Compound 3: no number, only a limit; the forecaster's own chance of this, stated with the estimate: 50%; the middle value sits exactly at the limit.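

In the Liver microsome assay compound 3 reads > 2 h, a limit of the assay and not a number, so a second group on the carbonyl carbon, this one holding sulfur, also reaches that limit: the limit of > 2 h in the Liver microsome assay, at which 2 of the 3 values shown sit.

In the Liver microsome assay, replacing the three-membered carbon ring group on the amine nitrogen gives an at least 13-fold higher number from compound 1 to compound 3 (1.12 log units; beyond the scatter). The step between the two limits cannot be read, whereas in a physicochemical assay for solubility, read by HPLC, at pH 6.8 (on this read-out higher numbers stand for higher solubility and lower numbers for lower solubility), there is no change at the digits printed from compound 2 to compound 3 (within the scatter). In the physicochemical assay compound 2 reads 68 ug/mL and compound 3 reads 68 ug/mL.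

As far as these compounds go, how long either compound lasts past the limit stays open. So does whether a morpholine ring or a dimethylamine on that carbonyl carbon would also reach it.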